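Swapping an Indole Amide for a Difluorobenzamide

The source may report more compounds than this note shows. Statements on the series, on what has been measured and on what is new or still open speak of the compounds shown alone.

Compound 1 `[O-][S+](CCNC1CCN(Cc2ccc(F)cc2)CC1)C(c1ccc(F)cc1)c1ccc(F)cc1`: in an assay on membranes from striatum (strain Sprague-Dawley) for displacement of a labelled ligand from sodium-dependent dopamine transporter (Rattus norvegicus), read by scintillation counting, with a stated time of 120 min (on this read-out lower numbers stand for stronger inhibition and higher numbers for weaker inhibition), compound 1 gives 50.6 nM
Compound 2 `O=C(c1cc2ccccc2[nH]1)N1CCC(NCCSC(c2ccc(F)cc2)c2ccc(F)cc2)CC1`: in this assay compound 2 gives 177 nM

Among the measured compounds shown here, compound 2 holds the higher of the two numbers; its only neighbour, compound 1, sits at a lower value, a gap that lies beyond the usual scatter. Compound 3 `O=C(c1ccc(F)cc1F)N1CCC(NCCSC(c2ccc(F)cc2)c2ccc(F)cc2)CC1` has not yet been measured. It differs from compound 2 in one place: 2,4-difluorophenyl in place of 1H-indol-2-yl on a carbonyl carbon. For the measured compounds named here, no measured pair shows this exchange, so its effect is unknown. A small step, not beyond the scatter, is expected in this assay: a 1.1-fold higher number from compound 2 to compound 3 (0.05 log units; within the scatter). Compound 3 is estimated at 200 nM, with a range from 70 nM to 600 nM.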

Compound 3, inhibition constant: 30 nM
Compound 3: middle estimate off by 6.7-fold (0.82 log units), on the high side; the measured number lies below the stated range.
By their numbers in this assay, from the lowest: compounds 3 and 1 (each within the scatter of the next); then compound 2.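

On the carbonyl carbon, 2,4-difluorophenyl in place of 1H-indol-2-yl gives in this assay a 5.9-fold lower number from compound 2 to compound 3 (0.77 log units; beyond the scatter) and so shows that this position responds to the group it carries. The exchange also removes the hydrogen-bond donor of 1H-indol-2-yl, but this single pair cannot separate that loss from the change of ring. Nothing available explains the drop in the number. Still open, going by these compounds, is whether an unsubstituted phenyl or a pyridine on the same carbonyl would give a similar number, and whether 1-methylindol-2-yl would stay close to compound 2.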